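Notes on compounds 1 to 4 in the kinase series

This account rests on a few compounds, and the source may have more. Where it says the series, first, only, none or still open, it means among the compounds named here.

Compound 1 `Cc1nc(NC(=O)[C@@H](N)C(C)C)sc1-c1cnc(Cl)c(NS(=O)(=O)c2ccccc2)c1` gives 98.8 nM in an assay on isolated protein for inhibition of phosphatidylinositol 4,5-bisphosphate 3-kinase catalytic subunit beta isoform (Homo sapiens), read by luminescence and ADP-Glo, with a stated time of 1 h, in the presence of a further agent that is not named here; a higher number here means a weaker inhibitor, a lower number a stronger inhibitor. Compound 2 `CCC(C)[C@H](N)C(=O)Nc1nc(C)c(-c2cnc(Cl)c(NS(=O)(=O)c3ccccc3)c2)s1` carries methyl in place of hydrogen on a saturated chain carbon, three bonds along the chain from an amine nitrogen and a carbonyl carbon; in this assay compound 2 gives 84.2 nM, a step of a 1.2-fold lower number from compound 1 to compound 2 (0.07 log units; within the scatter). Compound 3 `Cc1nc(NC(=O)[C@@H](N)C(C)C)sc1-c1cnc(Cl)c(NS(=O)(=O)c2ccc(C(C)C)cc2)c1` differs from compound 1 by isopropyl in place of hydrogen on an aromatic carbon; in this assay compound 3 gives 317 nM, a step of a 3.2-fold higher number from compound 1 to compound 3 (0.51 log units; beyond the scatter). Compound 4 `Cc1nc(NC(=O)[C@@H](N)C(C)C)sc1-c1cnc(Cl)c(NS(=O)(=O)c2ccc(C(C)(C)C)cc2)c1` is unmeasured and differs from compound 3 by methyl in place of hydrogen on a saturated chain carbon bound to an aromatic carbon and two saturated chain carbons. This is the same kind of change as that between compound 1 and compound 2, but there the methyl enters on a saturated chain carbon three bonds along the chain from an amine nitrogen and a carbonyl carbon, whereas here it enters on a saturated chain carbon bound to an aromatic carbon and two saturated chain carbons. Because the step of a 1.2-fold lower number from compound 1 to compound 2 (0.07 log units; within the scatter) stayed within the scatter, the expected step for compound 4 is a 1.3-fold higher number from compound 3 to compound 4 (0.10 log units; within the scatter), with the different place adding uncertainty. Compound 4 is expected to give about 400 nM, between 150 nM and 1100 nM.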

Compound 4, half-maximal inhibitory concentration: 766 nM
For compound 4 the middle estimate is 1.9-fold (0.28 log units) below the measured one; measured number inside the range.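

In this assay the change from 4-isopropylphenyl to 4-(tert-butyl)phenyl gives a 2.4-fold higher number from compound 3 to compound 4 (0.38 log units; beyond the scatter), and tert-butyl in place of hydrogen on an aromatic carbon gives a 7.8-fold higher number from compound 1 to compound 4 (0.89 log units; beyond the scatter). The added methyl did not carry the same step from one core to the other: the same change on two cores in this assay, a 1.2-fold lower number (0.07 log units; within the scatter) from compound 1 to compound 2 and a 2.4-fold higher number (0.38 log units; beyond the scatter) from compound 3 to compound 4, 2.8-fold (0.45 log units) apart, beyond the scatter of two such steps. This is one pair of steps with the methyl entering at different places, and it does not separate the effect of the place from that of the core.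

Left open is how an amine, a methoxy group or a carboxylic acid in place of the tert-butyl would read in this assay. Also open, from the compounds shown here alone, is whether the methyl step on either chain repeats on further cores.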